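Swapping the amide substituent of a weak thiophene-based agonist

This account rests on a few compounds, and the source may have more. Where it says the series, first, only, none or still open, it means among the compounds named here.

Measured so far:
- Compound 1 `Cc1ccc(OCC(=O)N(Cc2cccs2)C2CCCCC2)cc1`: 40000 nM
- Compound 2 `CCN(Cc1cccs1)C(=O)COc1ccc(Cl)cc1`: 39 nM
- Compound 3 `CCN(Cc1cccs1)C(=O)COc1ccc(C)cc1O`: 8 nM

In an assay on HEK293 cells for agonist activity at transient receptor potential cation channel subfamily M member 8 (Homo sapiens), read by fluorescence and calcium flux, with a stated time of 15 min (on this read-out lower numbers stand for an effect already at smaller amounts and higher numbers for an effect only at larger amounts of compound), compound 1 gives 40000 nM, the highest of the three numbers; compound 2 gives 39 nM and compound 3 gives 8 nM, both far lower. Compound 4 `Cc1ccc(OCC(=O)N(Cc2cccs2)c2ccon2)cc1` keeps the core of compound 1 and differs only in one place: 1,2-oxazol-3-yl in place of cyclohexyl on an amide-type nitrogen. Going by the values given here, no measured pair isolates this change, so the direction rests on the neighbouring compounds, which carry only a saturated chain carbon on the amide-type nitrogen and sit far below compound 1. The step in this assay is expected to go downward, and a 13-fold lower number from compound 1 to compound 4 (1.12 log units; beyond the scatter) is the estimated size. Compound 4 is expected to give 3000 nM, within 300 nM to 30000 nM.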

Compound 4, half-maximal effective concentration: 2 nM
Beside the measured number, compound 4's estimate is 1500-fold (3.18 log units) above it; measured number below the stated range.
By their numbers in this assay, from the lowest: compound 4; then compound 3; then compound 2; then compound 1.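

In this assay the core of compound 1 stays fixed, and 1,2-oxazol-3-yl in place of cyclohexyl on the amide-type nitrogen gives a 20000-fold lower number from compound 1 to compound 4 (4.30 log units; beyond the scatter) as a large step. The earlier compounds shown here offered no such single-place pair, and this one shows that this position alone can move the number this far, and that a ring here does not by itself keep the number high. Nothing measured here accounts for the size of the step. The compounds shown leave open whether a phenyl ring or a pyridin-2-yl group at this nitrogen would give a comparably low number.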